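This account rests on a few compounds, and the source may have more. Where it says the series, first, only, none or still open, it means among the compounds named here.

Measured compounds:
compound 1 `COc1cc(-c2nc3cc(/C=C4\SC(=O)NC4=O)ccc3[nH]2)cc(OC)c1OC` gives 13600 nM
compound 2 `COc1cc(-c2nc3cc(/C=C4\SC(=O)N(CC(=O)N5CCOCC5)C4=O)ccc3[nH]2)cc(OC)c1OC` gives 18800 nM
compound 3 `COc1cc(-c2nc3cc(/C=C4\SC(=O)N(CC(=O)N5CCCC5)C4=O)ccc3[nH]2)cc(OC)c1OC` gives 12700 nM

All three numbers come from an ADME assay on HEK-293T cells (Homo sapiens) for inhibition, read by MTT assay, with a stated time of 48 h; a lower number here means a stronger inhibitor, a higher number a weaker inhibitor. Compound 3 holds the lowest of the three numbers, yet its separation from compound 1 is a matter of a 1.1-fold lower number from compound 1 to compound 3 (0.03 log units; within the scatter) when read from compound 1, and from compound 2 only a 1.5-fold lower number from compound 2 to compound 3 (0.17 log units; within the scatter); neither gap reaches beyond the scatter, so compound 3 cannot be called the strongest of the set.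

Compound 4 `COc1cc(CN2C(=O)S/C(=C\c3ccc4[nH]c(-c5cc(OC)c(OC)c(OC)c5)nc4c3)C2=O)cc(OC)c1OC` has not yet been measured. It differs from compound 3 by 3,4,5-trimethoxyphenyl in place of (pyrrolidin-1-yl)carbonyl on a saturated chain carbon bound to an amide-type nitrogen in a ring. Within the data shown here, the steps that bear on this change are those at the same nitrogen: a 1.4-fold higher number from compound 1 to compound 2 (0.14 log units; within the scatter) and a 1.1-fold lower number from compound 1 to compound 3 (0.03 log units; within the scatter). Both show that exchanging the hydrogen on that nitrogen for a two-carbon chain ending in an amide leaves the number within the scatter. Among the measured compounds shown here, no measured step exchanges an amide at that position for an aromatic ring, so the present change reaches beyond what the data directly cover; still, with every substituent change at this nitrogen so far producing no movement beyond the scatter, the expected step of a 1.1-fold lower number from compound 3 to compound 4 (0.02 log units; within the scatter) is likewise none beyond the scatter. Compound 4 is therefore estimated at 12000 nM, within a range from 4000 nM to 40000 nM.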

Compound 4, half-maximal inhibitory concentration: 16600 nM
Estimate against measurement, compound 4: 1.4-fold (0.14 log units) below, and the stated range covers the measured number.
By their numbers in this assay, from the lowest: compounds 3, 1, 4 and 2 (each within the scatter of the next).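

In this assay, 3,4,5-trimethoxyphenyl on a saturated chain carbon bound to an amide-type nitrogen in a ring gives a 1.3-fold higher number from compound 3 to compound 4 (0.12 log units; within the scatter) when it takes the place of (pyrrolidin-1-yl)carbonyl, and a 1.1-fold lower number from compound 2 to compound 4 (0.05 log units; within the scatter) when it takes the place of (morpholin-4-yl)carbonyl. Among these compounds, until now this place had carried only hydrogen or a chain ending in an amide, so the result extends the finding: a six-membered aromatic ring of carbon only, which brings no amide carbonyl and more heavy atoms than either group it replaces, also leaves the number within the scatter, and every step read at this place so far does the same. Nothing at hand explains why the number responds so little to this exchange.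

The compounds shown leave open whether a carboxylic acid or an amine at the end of the chain, or a longer chain between the amide-type nitrogen and the ring, would move the number beyond the scatter. They also leave open whether a plain phenyl ring, without the three methoxy groups, would stay as close to compound 3 and compound 2 as the 3,4,5-trimethoxyphenyl group does.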